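The source may hold more compounds than are shown below. What is called first, only, known or untested is meant among the compounds shown, and "the series" means these compounds.

Measured compounds:
compound 1, `COc1ccc(F)cc1CNCCCNc1ccnc2cc(Oc3cccc(N(C)C)c3)ccc12`, 317 10^-6 cm/s in an ADME assay for permeability, using PAMPA, with a stated time of 30 min, at pH 7.4; on this read-out higher numbers stand for higher permeability and lower numbers for lower permeability
compound 2, `COc1ccc(F)cc1CNCCCNc1ccnc2cc(Cc3cccc(C(F)(F)F)c3)ccc12`, 23 10^-6 cm/s in this assay

Among the two numbers so far, compound 2 stands lowest, with compound 1 as its only neighbour, a step of a 14-fold lower number from compound 1 to compound 2 (1.14 log units; beyond the scatter). That single step, a swap of one group on an aromatic carbon of the shared core, shows that what sits at this position can move the read-out a great deal.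

Compound 3, `COc1ccc(F)cc1CNCCCNc1ccnc2cc(-c3cccc4ccccc34)ccc12`, is the next compound, not yet measured. It differs from compound 2 in one place: naphthalen-1-yl in place of 3-(trifluoromethyl)benzyl on an aromatic carbon. Going by the values given here, no measured step involves naphthalen-1-yl at this position, so the only guide is that the one known step, a 14-fold lower number from compound 1 to compound 2 (1.14 log units; beyond the scatter), was large, and that compound 2 itself gives 23 10^-6 cm/s. Among the compounds with values here, with no closer precedent, compound 3 is expected to stay near compound 2, with a change of about a 1.7-fold higher number from compound 2 to compound 3 (0.24 log units; within the scatter), inside the scatter. The estimate for compound 3 in this assay is 40 10^-6 cm/s, with a range from 10 10^-6 cm/s to 150 10^-6 cm/s.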

Compound 3, apparent permeability: 237 10^-6 cm/s
Beside the measured number, compound 3's estimate is 5.9-fold (0.77 log units) below it; the measured number lies above the stated range.
By their numbers in this assay, from the lowest: compound 2; then compounds 3 and 1 (each within the scatter of the next).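

In this assay, a 10-fold higher number from compound 2 to compound 3 (1.01 log units; beyond the scatter) shows that the low number of compound 2 does not hold for every group without a nitrogen or oxygen at this position. The other new step, a 1.3-fold lower number from compound 1 to compound 3 (0.13 log units; within the scatter), lies within the scatter, so naphthalen-1-yl and 3-(dimethylamino)phenoxy give numbers that cannot be told apart, although the two groups look quite different. Among these three compounds, 3-(trifluoromethyl)benzyl alone goes with the low number, and nothing measured here explains why.

The compounds shown do not separate the trifluoromethyl group from the methylene link of the benzyl group, as the two always appear together. A plain benzyl group or a 3-(trifluoromethyl)phenoxy group at this position would show which of the two parts goes with the low number.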